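A few compounds are considered here, and "the series" means these few. Any claim that something is new, unique, unknown or untested is made for them only; others in the source may bear on it.

Measured so far:
compound 1 `Cc1c(Nc2nc(N)c3c(C#N)c(N4CCC[C@H]4C)n(C)c3n2)cnn1[C@@H]1CCOC1`: 28.3 mL/min/kg
compound 2 `C[C@@H]1CCCN1c1c(C#N)c2c(N)nc(Nc3cn(C)nc3C(F)(F)F)nc2n1C`: 33.3 mL/min/kg

Both were tested in an ADME assay on microsomes from liver (Homo sapiens) for pharmacokinetics; on this read-out lower numbers stand for slow clearance and higher numbers for fast clearance. Compound 1 gives 28.3 mL/min/kg, the lower of the two numbers, but compound 2 gives 33.3 mL/min/kg, which lies within the scatter of that value, so the two cannot be told apart. Compound 3 `Cc1c(Nc2nc(N)c3c(C#N)c(N4CCC[C@H]4C)n(C)c3n2)cnn1[C@H]1CCOC1` has not yet been measured. It differs from compound 1 in this way: the two compounds have the same atoms and bonds and differ only in configuration as drawn: 1 of 2 stereo elements differ; a stereocentre at a saturated ring carbon is drawn R in compound 1 and S in compound 3. Within the data shown here, no step between measured compounds is available to guide the expectation, and a change of configuration alone is expected to shift this assay by nothing beyond the scatter, in no set direction. The expected step of a 1.0-fold lower number from compound 1 to compound 3 (0.00 log units; within the scatter) is therefore small. Compound 3 is estimated at 28 mL/min/kg, between 15 mL/min/kg and 55 mL/min/kg.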

Compound 3, clearance: 23.3 mL/min/kg
Compound 3: middle estimate off by 1.2-fold (0.08 log units), on the high side; the range from low to high includes it.
By their numbers in this assay, from the lowest: compounds 3, 1 and 2 (each within the scatter of the next).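

Among these compounds, the earlier compounds held no pair differing in one place, so a stereocentre at a saturated ring carbon can now be read on its own for the first time. Going from R to S gives a 1.2-fold lower number from compound 1 to compound 3 (0.08 log units; within the scatter) in this assay, so the configuration at this carbon does not separate the two compounds. Nothing else enters this comparison: the fact that compounds 1 and 3 differ only in the configuration as drawn

The pair speaks only to this one carbon. From the compounds shown here alone, whether another group at this place, such as an amine or a carboxylic acid, would move the number beyond the scatter stays open.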